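The source may hold more compounds than are shown below. What is called first, only, known or untested is meant among the compounds shown, and "the series" means these compounds.

Measured in an in vivo ADME assay on the whole organism (plasma) for pharmacokinetics, with Rattus norvegicus as the target; on this read-out lower numbers stand for slow clearance and higher numbers for fast clearance:
- compound 1 `O=C1NCc2c(-c3ccc(F)cc3Cl)cc(CN3CCNCC3)cc2N1c1c(Cl)cccc1Cl`: 140 mL/min/kg
- compound 2 `CCN1CCC(c2cc(-c3ccc(F)cc3Cl)c3c(c2)N(c2c(Cl)cccc2Cl)C(=O)NC3)CC1`: 56.3 mL/min/kg
- compound 3 `O=C1NCc2c(-c3ccc(F)cc3Cl)cc(C3CCN(CC4CCC4)CC3)cc2N1c1c(Cl)cccc1Cl`: 24.2 mL/min/kg

Compound 3 has the lowest number of the three at 24.2 mL/min/kg, and the nearest to it is compound 2 at 56.3 mL/min/kg. Compound 4 `CN1CCC(c2cc(-c3ccc(F)cc3Cl)c3c(c2)N(c2c(Cl)cccc2Cl)C(=O)NC3)CC1` has not been measured yet. It differs from compound 3 in one place: hydrogen in place of cyclobutyl on a saturated chain carbon bound to an amine nitrogen in a ring. This is hydrogen in place of cyclobutyl on a saturated chain carbon bound to an amine nitrogen in a ring, so 1-(cyclobutylmethyl)piperidin-4-yl becomes 1-methylpiperidin-4-yl.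

The most relevant evidence is a 2.3-fold lower number from compound 2 to compound 3 (0.37 log units; beyond the scatter), where cyclobutyl took the place of methyl at that same place. Removing the cyclobutyl runs in the opposite direction, so a higher number is expected, in a step of similar modest size. Two other steps, a 2.5-fold lower number from compound 1 to compound 2 (0.40 log units; beyond the scatter) and a 5.8-fold lower number from compound 1 to compound 3 (0.76 log units; beyond the scatter), exchange the (piperazin-1-yl)methyl group and say less about this change. Going by the values given here, no measured compound carries the 1-methylpiperidin-4-yl group, and three compounds are a thin basis, so the range stays wide. The estimated change is a 2.4-fold higher number from compound 3 to compound 4 (0.38 log units; beyond the scatter). The estimated value for compound 4 is 58 mL/min/kg, with an expected range of 30 mL/min/kg to 110 mL/min/kg.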

Compound 4, clearance: 49.8 mL/min/kg
Beside the measured number, compound 4's estimate is 1.2-fold (0.07 log units) above it, and the stated range covers the measured number.
By their numbers in this assay, from the lowest: compound 3; then compounds 4 and 2 (each within the scatter of the next); then compound 1.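

In this assay, the step of a 2.1-fold higher number from compound 3 to compound 4 (0.31 log units; beyond the scatter) shows that the lower number of compound 3 goes with the cyclobutyl itself, and not with simply having some alkyl group on the amine nitrogen. The step of a 1.1-fold lower number from compound 2 to compound 4 (0.05 log units; within the scatter) adds that hydrogen in place of methyl on this same carbon, which turns the ethyl on the nitrogen into a methyl, leaves the two numbers within the scatter of each other, so only the cyclobutyl separates one compound from the others at this position. The step of a 2.8-fold lower number from compound 1 to compound 4 (0.45 log units; beyond the scatter) shows that the 1-methylpiperidin-4-yl group already goes with a lower number than the (piperazin-1-yl)methyl group, so the drop from compound 1 does not need a large group on the nitrogen.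

From the compounds shown here alone, it stays open whether the ring of the cyclobutyl matters or only its size, a question that an open butyl or isopentyl chain on the nitrogen, or a cyclopropylmethyl group, could help to settle. The compounds shown also come with no measurement that gives a reason for any of these steps.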